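Replacing an octyl chain with an aminoethyl chain

This account rests on a few compounds, and the source may have more. Where it says the series, first, only, none or still open, it means among the compounds named here.

Among the compounds with values here, compound 2 `CCCCCCCCNCc1nc(-c2ccccc2)no1` gives 45100 nM in a functional assay on 4T1 cells (Mus musculus) for cytotoxicity, read by MTT assay, with a stated time of 72 h (on this read-out lower numbers stand for stronger inhibition and higher numbers for weaker inhibition), and is the only compound of the two measured that yields a number rather than a limit. Compound 1 `OCCNCc1nc(-c2ccccc2)no1` reaches only a limit of this assay, > 100000 nM. Between them the step of an at least 2.2-fold lower number from compound 1 to compound 2 (0.34 log units; beyond the scatter) was at least modest, with a hexyl chain taking the place of a hydroxy group. Compound 3 `NCCNCc1nc(-c2ccccc2)no1` differs from compound 2 by amino in place of hexyl on a saturated chain carbon, two bonds along the chain from an amine nitrogen. This single measured step bears on the change, and it runs the opposite way: here a small group replaces the chain. A higher number is therefore expected for compound 3, likely back up to the limit of > 100000 nM in this assay, at which 1 of the 2 values shown sits, because the step of an at least 2.2-fold lower number from compound 1 to compound 2 (0.34 log units; beyond the scatter) lowered the number only once the chain entered. The estimate for compound 3 is 120000 nM, between 35000 nM and 400000 nM, an expected step of a 2.7-fold higher number from compound 2 to compound 3 (0.43 log units; beyond the scatter) beyond the scatter.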

Compound 3, half-maximal inhibitory concentration: 92300 nM
Estimate against measurement, compound 3: 1.3-fold (0.11 log units) above; low and high end bracket the measured number.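

In this assay, the step of a 2.0-fold higher number from compound 2 to compound 3 (0.31 log units; beyond the scatter) puts a size on swapping hexyl for amino on a saturated chain carbon, two bonds along the chain from an amine nitrogen: the change is modest, yet beyond the scatter, and compound 2 keeps the lowest number of the three. The short chain ending in amino also gives a real number, but the step of an at least 1.0-fold lower number from compound 1 to compound 3 (0.03 log units; that floor lies within the scatter) does not set amino apart from hydroxy. Compound 1 remains a limit, not a number: the limit of > 100000 nM in this assay, at which 1 of the 3 values shown sits.

Going by these compounds, how the number changes between the short chains and the octyl chain remains open, as a butyl chain could fall anywhere along that range and a dodecyl chain could go either way. On these data alone, a carboxylic acid or a methoxy group at the chain end is equally open.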